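This account rests on a few compounds, and the source may have more. Where it says the series, first, only, none or still open, it means among the compounds named here.

Three compounds share one core and differ only in the group on the amide-bearing ring. Compound 1 `CO/C(=C\c1ccccc1)C(=O)Nc1ccc(F)cc1` carries fluoro and, in a functional assay on cells (Splenocyte, Mus musculus, strain BALB/c) for inhibition, read by MTT assay, with a stated time of 48 h (a higher number here means a weaker inhibitor, a lower number a stronger inhibitor), compound 1 gives 4940 nM. Compound 2 `CO/C(=C\c1ccccc1)C(=O)Nc1ccc(C)cc1` carries methyl, and compound 2 gives 16600 nM. Compound 3 `CO/C(=C\c1ccccc1)C(=O)Nc1ccc(C(C)C)cc1` carries isopropyl, and compound 3 gives 3460 nM. Compound 2 thus stands highest of the three, meaning the weakest inhibitor, since a 3.4-fold higher number from compound 1 to compound 2 (0.53 log units; beyond the scatter) and a 4.8-fold lower number from compound 2 to compound 3 (0.68 log units; beyond the scatter), while a 1.4-fold lower number from compound 1 to compound 3 (0.15 log units; within the scatter).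

Compound 4 `CO/C(=C\c1ccc(Br)cc1)C(=O)Nc1ccc(C)cc1` keeps the methyl of compound 2 and adds a group elsewhere: bromo in place of hydrogen on an aromatic carbon. The bromo enters on the other six-membered aromatic ring of carbon only, para to a large group.

For the measured compounds named here, none of the measured steps touches that ring; all three change the group on the amide-bearing ring. So the measured steps give no guide to how this change will move the number, and the expectation rests only on the fact that the rest of compound 4 matches compound 2. Compound 4 is therefore expected to give 13000 nM, a step of a 1.3-fold lower number from compound 2 to compound 4 (0.11 log units; within the scatter) that is expected to lie within the scatter, with a wide range from 4000 nM to 40000 nM to reflect the lack of any bearing step.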

Compound 4, half-maximal inhibitory concentration: 12900 nM
Estimate against measurement, compound 4: 1.0-fold (0.00 log units) above, within the range that was stated.
By their numbers in this assay, from the lowest: compounds 3 and 1 (each within the scatter of the next); then compounds 4 and 2 (each within the scatter of the next).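

Adding bromo to the other six-membered ring, which turns phenyl into 4-bromophenyl para to a large group, gives a 1.3-fold lower number from compound 2 to compound 4 (0.11 log units; within the scatter) in this assay, so compound 4 cannot be told apart from compound 2 in this test. For the compounds shown here, this is the first look at a change away from the amide-bearing ring, where swapping one group for another could shift the number beyond the scatter, as in a 4.8-fold lower number from compound 2 to compound 3 (0.68 log units; beyond the scatter) for example. Here, with methyl kept on the amide-bearing ring, a whole new bromine atom on the other ring leaves the reading where it was, and no supporting measurement is available to explain this result.

A single bromo on a methyl-bearing compound cannot show whether the same addition would be just as silent alongside the fluoro of compound 1 or the isopropyl of compound 3. The compounds shown also leave open whether a different group at this same place, such as an amine, a carboxylic acid or a longer chain, would move the number beyond the scatter.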